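The source may report more compounds than this note shows. Statements on the series, on what has been measured and on what is new or still open speak of the compounds shown alone.

Measured so far in an assay on isolated protein for inhibition of Amine oxidase [flavin-containing] B (Homo sapiens), read by spectrophotometry; on this read-out lower numbers stand for stronger inhibition and higher numbers for weaker inhibition:

compound 1 `COc1ccc(/C=N/Nc2nc3ccccc3nc2Cc2ccccc2)cc1OC` — 460000 nM
compound 2 `C/C(=N\Nc1nc2ccccc2nc1Cc1ccccc1)c1ccccn1` — 980000 nM

Compound 2 stands at the highest of the two numbers; the nearest is compound 1, whose number is lower, and that gap lies beyond the usual scatter. Compound 3 `Cc1ccsc1/C=N/Nc1nc2ccccc2nc1Cc1ccccc1` is not yet measured. It differs from compound 2 in one place: a group of 8 heavy atoms (6 carbon, 1 nitrogen, 1 sulfur; one five-membered aromatic ring with 1 hetero atom) in place of a group of 9 heavy atoms (7 carbon, 2 nitrogen; one six-membered aromatic ring with 1 hetero atom), on a nitrogen on an aromatic ring. Going by the values given here, no measured pair shows this kind of exchange, so there is no step to lean on. Both numbers seen are very high, and nothing in the two values argues for a large move in either direction. For compound 3 a step of a 1.4-fold lower number from compound 2 to compound 3 (0.15 log units; within the scatter) is expected, which is within the scatter around compound 2. Compound 3 is estimated at 700000 nM, with a range of 300000 nM to 1600000 nM.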

Compound 3, half-maximal inhibitory concentration: 860000 nM
For compound 3 the middle estimate is 1.2-fold (0.09 log units) below the measured one; measured number inside the range.
By their numbers in this assay, from the lowest: compounds 1, 3 and 2 (each within the scatter of the next, the first and the last beyond it).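

In this assay, replacing the pyridine-type six-membered aromatic group with a sulfur-containing five-membered aromatic group, on a nitrogen on an aromatic ring, gives a 1.1-fold lower number from compound 2 to compound 3 (0.06 log units; within the scatter), so this change of ring size and hetero atom does not separate the two compounds. Exchanging 3,4-dimethoxyphenyl for 3-methylthiophen-2-yl on a carbon with a double bond to nitrogen gives a 1.9-fold higher number from compound 1 to compound 3 (0.27 log units; within the scatter), so neither step shows a real effect at this position, and all three numbers remain very high. No measurement bears on why these exchanges leave the number so little changed.

As far as these compounds go, whether a carboxylic acid or an amine on this ring, or an open alkyl chain in its place, would move the number beyond the scatter remains open. From the compounds shown here alone, the effect of any change to the shared core also remains open, since the core is the same in all three compounds.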